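From Benzylamino to Phenylsulfanyl on a Shared Core

The compounds below may be only part of what the source reports. "The series", "measured", "known", "first", "only" and "open" are said of these compounds alone.

Three compounds share one core and differ only in the group attached to it. In a functional assay on MCF7 cells (Homo sapiens) for inhibition, read by sulforhodamine B assay, with a stated time of 48 h (on this read-out lower numbers stand for stronger inhibition of growth and higher numbers for weaker inhibition of growth), compound 1 `Nc1cc(N)c2nc(-c3ccccc3)c(NCc3ccc(Cl)c(Cl)c3)nc2c1` gives 12300 nM. Compound 2 `Nc1cc(N)c2nc(-c3ccccc3)c(NCc3ccc(F)cc3)nc2c1` gives 3020 nM, and compound 3 `COc1ccc(CNc2nc3cc(N)cc(N)c3nc2-c2ccccc2)cc1` gives 13200 nM. Compound 2 thus stands lowest of the three: a 4.1-fold lower number from compound 1 to compound 2 (0.61 log units; beyond the scatter), a 4.4-fold higher number from compound 2 to compound 3 (0.64 log units; beyond the scatter), while a 1.1-fold higher number from compound 1 to compound 3 (0.03 log units; within the scatter).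

Compound 4 `Nc1cc(N)c2nc(-c3ccccc3)c(Sc3ccc(F)cc3)nc2c1` has not been measured. It differs from compound 2 in one place: (4-fluorophenyl)sulfanyl in place of (4-fluorobenzyl)amino on an aromatic carbon. All three measured steps only exchange substituents on the outer aromatic ring while keeping the saturated chain carbon and its nitrogen, so none of them covers the loss of that chain and its hydrogen-bond donor. The measured steps show that changes in this region move the number only modestly, and the new change is larger than any of them. Compound 4 is therefore expected to give a weaker result than compound 2, with an estimated 2.3-fold higher number from compound 2 to compound 4 (0.37 log units; beyond the scatter). The estimate for compound 4 is 7000 nM, within a range from 1500 nM to 30000 nM.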

Compound 4, concentration for 50% growth inhibition: 20000 nM
Estimate against measurement, compound 4: 2.9-fold (0.46 log units) below; measured number inside the range.
By their numbers in this assay, from the lowest: compound 2; then compounds 1, 3 and 4 (each within the scatter of the next).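

The earlier steps shown here changed only the substituent on the outer ring, whereas this one changes the link between that ring and the shared core. In this assay, placing (4-fluorophenyl)sulfanyl where (4-fluorobenzyl)amino stood gives a 6.6-fold higher number from compound 2 to compound 4 (0.82 log units; beyond the scatter) and is the largest step seen so far, so with the 4-fluorophenyl ring kept, the link alone can shift growth inhibition beyond the scatter. No available evidence explains this shift.

The change removes the chain carbon and the nitrogen with its hydrogen-bond donor and brings in sulfur, all in one step, so the compounds shown leave open which of these differences matters. A (4-fluorophenyl)amino group, which keeps the nitrogen without the chain carbon, and a (4-fluorobenzyl)sulfanyl group, which keeps the chain carbon with sulfur, would pull these differences apart.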